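A few compounds are considered here, and "the series" means these few. Any claim that something is new, unique, unknown or untested is made for them only; others in the source may bear on it.

Compound 1 `COc1cccc(Cc2ccnn(CC(=O)Nc3ccc(Br)cc3)c2=O)c1` gives > 50000 nM in a functional assay on HL-60 cells (Homo sapiens), read by calcium flux; on this read-out lower numbers stand for an effect already at smaller amounts and higher numbers for an effect only at larger amounts of compound; this is a limit of the assay, not a number.
Compound 2 `COc1cccc(Cc2cc(C(C)C)nn(CC(=O)Nc3ccc(Br)cc3)c2=O)c1` gives > 50000 nM in this assay; this too is a limit.
Compound 3 `COc1ccc(Cc2cc(-c3cccs3)nn(CC(=O)Nc3ccc(Br)cc3)c2=O)cc1` gives > 50000 nM in this assay; again only a limit.

Compound 3 therefore stands where every measured compound stands, at the limit of > 50000 nM in this assay, at which 3 of the 3 values shown sit, and no number is known for it. Among the measured compounds shown here, the only step among measured compounds, a step that the two limits leave unreadable from compound 1 to compound 2, runs between two limits and cannot be read; it also concerns a different group. Compound 4 `COc1ccc(Cc2cc(-c3ccc(Cl)cc3)nn(CC(=O)Nc3ccc(Br)cc3)c2=O)cc1` differs from compound 3 by 4-chlorophenyl in place of thiophen-2-yl on an aromatic carbon. No measured step bears on this change, so neither its direction nor its size can be read from the data shown. The expectation for compound 4 in this assay is estimated at 50000 nM, with a range from 8000 nM to 200000 nM, most likely reported again as a limit. That expected value means an estimated step of a number no higher from compound 3 to compound 4 (the limit leaves the size open) from compound 3 to compound 4, which is no step beyond the scatter.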

Compound 4, half-maximal effective concentration: > 50000 nM
Compound 4: a limit, no number; the forecaster's own chance of this, stated with the estimate: 80%; the middle value sits exactly at the limit.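

Compound 3 and compound 4 both give only a limit, not a number, so the step between them cannot be read. The compounds shown leave open whether any change to the shared core yields a measurable number at all: the limit of > 50000 nM in this assay, at which 4 of the 4 values shown sit.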